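Moving from 2-methoxyphenyl to 3-bromophenyl in the series

This account rests on a few compounds, and the source may have more. Where it says the series, first, only, none or still open, it means among the compounds named here.

Of the compounds shown here, three on a shared core have been measured in a functional assay on L1210 cells (Mus musculus) for antiproliferative activity, read by MTT assay, with a stated time of 72 h; on this read-out lower numbers stand for stronger inhibition and higher numbers for weaker inhibition. Compound 1 (`COc1ccc(C2=NN(C(C)=O)C(c3cccc([N+](=O)[O-])c3)O2)cc1`) gives 47000 nM, compound 2 (`COc1ccc(C2=NN(C(C)=O)C(c3cccc(OC)c3)O2)cc1`) gives 41000 nM, and compound 3 (`COc1ccc(C2=NN(C(C)=O)C(c3ccccc3OC)O2)cc1`) gives 5800 nM. Compound 3 holds the lowest number of the three, and its gaps to the other two lie beyond the scatter.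

Next in line is compound 4 (`COc1ccc(C2=NN(C(C)=O)C(c3cccc(Br)c3)O2)cc1`), which has 3-bromophenyl in place of 2-methoxyphenyl on a saturated ring carbon.

Among the measured compounds shown here, two measured steps bear on this change. Methoxy in place of nitro on an aromatic carbon gave a 1.1-fold lower number from compound 1 to compound 2 (0.06 log units; within the scatter), a step within the scatter. 2-Methoxyphenyl in place of 3-methoxyphenyl gave a 7.1-fold lower number from compound 2 to compound 3 (0.85 log units; beyond the scatter), a modest step beyond the scatter. Compound 4 gives up the 2-methoxyphenyl group of compound 3 and, like the 3-methoxyphenyl of compound 2, carries a group named at the 3-position. For the measured compounds named here, no bromine-bearing compound has been measured, so the effect of bromine itself remains open.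

A modest rise, towards weaker inhibition, is expected, with an estimated 6.0-fold higher number from compound 3 to compound 4 (0.78 log units; beyond the scatter). Compound 4 is estimated at 35000 nM, with an expected range from 15000 nM to 70000 nM.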

Compound 4, half-maximal inhibitory concentration: 37000 nM
Estimate against measurement, compound 4: 1.1-fold (0.02 log units) below; measured number inside the range.
By their numbers in this assay, from the lowest: compound 3; then compounds 4, 2 and 1 (each within the scatter of the next).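

In this assay, bromo in place of methoxy on the aromatic carbon gives a 1.1-fold lower number from compound 2 to compound 4 (0.04 log units; within the scatter), and bromo in place of nitro gives a 1.3-fold lower number from compound 1 to compound 4 (0.10 log units; within the scatter), so the three groups tried on this phenyl ring in compounds 1, 2 and 4 cannot be told apart at this read-out. Compound 3 stands apart from this set, with a 6.4-fold higher number from compound 3 to compound 4 (0.80 log units; beyond the scatter) for 3-bromophenyl in place of 2-methoxyphenyl on the saturated ring carbon; among the compounds shown, the lower number goes with 2-methoxyphenyl alone and not with methoxy as such, as compound 2 carries 3-methoxyphenyl and sits with the bromo and nitro compounds. No measured evidence is available that accounts for this difference.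

As far as these compounds go, it remains open whether the lower number of compound 3 depends on the methoxy group itself or would hold with bromo in its place on the same ring carbon. Also open is how an amine or a carboxylic acid on this phenyl ring would read out, since all the groups shown so far are neutral in the counts given and none is of either kind.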